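The source may report more compounds than this note shows. Statements on the series, on what has been measured and on what is new or still open speak of the compounds shown alone.

Of the compounds shown here, three sharing one core have been tested in a functional assay on MDA-MB-435 cells (Homo sapiens) for cytotoxicity, read by sulforhodamine B assay, with a stated time of 48 h; a lower number here means a stronger inhibitor of growth, a higher number a weaker inhibitor of growth. Compound 1 `ClCc1ccc(Cn2cnc3c(Cl)ncnc32)cc1` gives 1620 nM. Compound 2 `ClCc1ccccc1Cn1cnc2c(Cl)nc(Cl)nc21` gives 1620 nM, level with compound 1 at the digits shown, and the two stand together at the low end of the three numbers. Compound 3 `ClCc1cccc(Cn2cnc3c(Cl)nc(Cl)nc32)c1` gives 1690 nM, a number that differs from that of compound 2 by so little that the two cannot be told apart within the scatter. So the three measured compounds behave alike, and nothing separates them.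

Compound 4 `Nc1nc(Cl)c2ncn(Cc3ccccc3CCl)c2n1` has not yet been tested. It differs from compound 2 in one place: amino in place of chloro on an aromatic carbon. Among the measured compounds shown here, no pair among the measured compounds shows what such a swap does in this assay, so no measured step can guide the estimate. The three measured numbers sit close together, and the change in compound 4 is confined to a single group. The step is expected to be small, a 1.4-fold higher number from compound 2 to compound 4 (0.13 log units; within the scatter), if anything toward a slightly higher number. Compound 4 is therefore estimated at 2200 nM, within a range from 800 nM to 6500 nM.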

Compound 4, concentration for 50% growth inhibition: 6030 nM
Beside the measured number, compound 4's estimate is 2.7-fold (0.44 log units) below it; low and high end bracket the measured number.
By their numbers in this assay, from the lowest: compounds 1, 2 and 3 (each within the scatter of the next); then compound 4.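

Among the compounds shown here, the earlier compounds offered no pair differing in one place, so this is the first measured sign that a single swap on the shared core can move the result. In this assay, amino in place of chloro on the aromatic carbon between two ring nitrogen atoms gives a 3.7-fold higher number from compound 2 to compound 4 (0.57 log units; beyond the scatter) and so a modest step beyond the scatter. At this position, chloro therefore goes with the stronger growth inhibition of the pair, though no measured evidence is available to explain the difference.

This one pair cannot separate the effect of losing chloro from that of gaining amino. A methoxy or methylamino group at the same carbon would show whether other replacements for chloro give a similar step.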